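The compounds below may be only part of what the source reports. "The series", "measured", "known", "first", "only" and "open" are said of these compounds alone.

Working notes on the series. In an assay for binding affinity to Corticotropin releasing factor receptor (Rattus norvegicus) (a lower number here means a stronger inhibitor, a higher number a weaker inhibitor), compound 1 `CCc1nc2c(-c3ccc(Cl)cc3Cl)ccnc2n1C(CCOC)C1CCC1` gives 2.4 nM, compound 3 `CCc1nc2c(-c3ccc(C(F)(F)F)cc3Cl)ccnc2n1C(CC)COC` gives 4.7 nM, and compound 2 `CCCC(C)n1c(CC)nc2c(-c3ccc(C(C)OC)cc3Cl)ccnc21` gives 3.5 nM. Compound 2 thus stands second of the three numbers, and both its neighbours lie within the usual scatter of it: compound 3 is the nearer, compound 1 the further, and neither gap supports a ranking. All three compounds share one core and vary the substituents on the attached aromatic ring and on the nitrogen chain.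

Compound 4 `CCCC(C)n1c(CC)nc2c(-c3ccc(C(C)=O)cc3Cl)ccnc21` is not yet measured in this assay. Its difference from compound 2 is counted as acetyl in place of 1-methoxyethyl on an aromatic carbon. Going by the values given here, no step between measured compounds reproduces this kind of change, so the expectation rests only on the three values above and the nature of the swap. A modest loss is expected, the step from compound 2 to compound 4 being estimated at a 2.3-fold higher number from compound 2 to compound 4 (0.36 log units; beyond the scatter), but still inside a range that overlaps the measured compounds. Compound 4 is expected to give about 8 nM in this assay, with a plausible range from 2.5 nM to 25 nM.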

Compound 4, inhibition constant: 1 nM
Beside the measured number, compound 4's estimate is 8.0-fold (0.90 log units) above it; measured number outside the range, below it.
By their numbers in this assay, from the lowest: compound 4; then compounds 1, 2 and 3 (each within the scatter of the next).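

In this assay, going by these compounds alone, acetyl in place of 1-methoxyethyl gives a 3.5-fold lower number from compound 2 to compound 4 (0.54 log units; beyond the scatter), the only step so far that isolates a single change. It shows that this aromatic carbon, meta to a chloro group and para to a large group, responds to the group it carries by more than the scatter, and that one heavy atom fewer with the same count of hydrogen-bond acceptors brings no loss here. No measurement at hand bears on why the number moves this way.

As far as these compounds go, it remains open whether the carbonyl or the removal of the methoxy part accounts for the step, which 1-hydroxyethyl, a primary amide or a nitrile on the same carbon could help separate. From the compounds shown here alone, it also remains open whether the same swap carries over to the nitrogen chains of compound 1 and compound 3.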